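The source may report more compounds than this note shows. Statements on the series, on what has been measured and on what is new or still open speak of the compounds shown alone.

Of the compounds shown here, three that share one core have been measured in an assay on isolated protein for inhibition of RAC-alpha serine/threonine-protein kinase (Homo sapiens), read by fluorescence, with a stated time of 30 min, tested at 10 uM; on this read-out lower numbers stand for less inhibition and higher numbers for more inhibition at the one concentration tested (going by the name of the read-out). Compound 1 `O=C(Nc1cc(Sc2ncn[nH]2)c(O)c2ccccc12)c1ccc(Cl)cc1` gives 50.1%, compound 2 `O=C(Nc1cc(Sc2ncn[nH]2)c(O)c2ccccc12)c1cccc(Cl)c1` gives 46%, and compound 3 `O=C(Nc1cc(Sc2ncn[nH]2)c(O)c2ccccc12)c1cccc([N+](=O)[O-])c1` gives 29.3%. Compound 3 stands lowest of the three: the gap to compound 2 and the gap to compound 1 are both beyond the usual scatter, whereas compound 1 and compound 2 sit within the scatter of each other.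

The next compound, compound 4 `O=C(/C=C/c1ccc(Cl)cc1)Nc1cc(Sc2ncn[nH]2)c(O)c2ccccc12`, differs from compound 3 in one place: 2-(4-chlorophenyl)ethenyl in place of 3-nitrophenyl on a carbonyl carbon. Among the compounds with values here, two measured steps bear on this. The step of a number 20.8 percentage points lower from compound 1 to compound 3 (beyond the scatter) and the step of a number 16.7 percentage points lower from compound 2 to compound 3 (beyond the scatter) both show that the 3-nitrophenyl group goes with a lower number than either chlorophenyl group. Within the data shown here, compound 4 returns a 4-chlorophenyl ring, now carried on a two-carbon ethenyl link; no measured compound carries such a link, so its own effect is unknown. The expected step is therefore a number 15.7 percentage points higher from compound 3 to compound 4 (beyond the scatter), upward, back toward the level of compound 1 at 50.1%. Compound 4 is estimated at 45%, between 25% and 65%.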

Compound 4, a percentage reported as inhibition, at one concentration (the size of the read-out at that concentration, not a potency): 31.8%
Compound 4: middle estimate off by 13.2 percentage points, on the high side; the measured number falls inside the stated range.
By their numbers in this assay, from the lowest: compounds 3 and 4 (each within the scatter of the next); then compounds 2 and 1 (each within the scatter of the next).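

In this assay, the new result shows that a 4-chlorophenyl ring does not give the same number once an ethenyl link separates it from the carbonyl carbon: the data show a number 18.3 percentage points lower from compound 1 to compound 4 (beyond the scatter) and also a number 14.2 percentage points lower from compound 2 to compound 4 (beyond the scatter) as the comparison with the 3-chlorophenyl group. So the chlorine-bearing ring alone does not set the level at this position, and what joins it to the carbonyl carbon also goes with a difference. With a number 2.5 percentage points higher from compound 3 to compound 4 (within the scatter), 2-(4-chlorophenyl)ethenyl and 3-nitrophenyl cannot be told apart here, and nothing measured here gives a reason for these steps.

From the compounds shown here alone, it remains open whether the ethenyl link itself matters or only the greater reach of the group. An ethyl chain in its place, or an amine on the ring, would help to separate these possibilities.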